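A few compounds are considered here, and "the series" means these few. Any claim that something is new, unique, unknown or untested is made for them only; others in the source may bear on it.

Measured so far:
compound 1, `CCOC(=O)c1sc(NC(=O)Cn2cc(-c3ccc(F)cc3)nn2)nc1C`: 660 nM
compound 2, `O=C(Cn1cc(-c2ccccc2Cl)nn1)Nc1nc2ccccc2s1`: > 30000 nM
compound 3, `Cc1csc(NC(=O)Cn2cc(-c3ccc(F)cc3)nn2)n1`: 250 nM

In a functional assay on BMDM cells (Mus musculus, strain C57BL/6) for inhibition, with a stated time of 2 days (on this read-out lower numbers stand for stronger inhibition and higher numbers for weaker inhibition), compound 1 gives 660 nM, the higher of the two numbers obtained. Within the data shown here, compound 3 gives 250 nM, and the single measured step is a 2.6-fold lower number from compound 1 to compound 3 (0.42 log units; beyond the scatter). Compound 2 gives only > 30000 nM, which is a limit of the assay and not a number. That reading of compound 2 is the limit of > 30000 nM in this assay, at which 1 of the 3 values shown sits.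

Compound 4, `CCOC(=O)c1sc(NC(=O)Cn2cc(-c3ccc([N+](=O)[O-])cc3)nn2)nc1C`, differs from compound 1 in one place: nitro in place of fluoro on an aromatic carbon. Among the measured compounds shown here, the only measured step, from compound 1 to compound 3, changes a group on the shared core, not the six-membered ring that carries the fluoro, so it gives no guide to this change, and no measured compound carries a nitro. With nothing to point either way, the expected step is a 1.1-fold higher number from compound 1 to compound 4 (0.03 log units; within the scatter), that is, no change beyond the scatter. For compound 4 the estimate in this assay is therefore 700 nM, within a range from 200 nM to 3000 nM.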

Compound 4, half-maximal inhibitory concentration: 1840 nM
The estimate for compound 4 lay 2.6-fold (0.42 log units) below the measured number; the range from low to high includes it.
By their numbers in this assay, from the lowest: compound 3; then compound 1; then compound 4. At a limit, above all of these: compound 2.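

Before this, the only measured step changed a group on the shared core, and nothing showed how the group para to a large group on the six-membered ring affects the read-out. In this assay the change from 4-fluorophenyl to 4-nitrophenyl gives a 2.8-fold higher number from compound 1 to compound 4 (0.45 log units; beyond the scatter) and so shows that this position responds to what it carries, while the step is modest and compound 4 still gives a measured number and not a limit. Nothing measured here accounts for the direction or size of this step.

The compounds shown leave open whether an amine, a carboxylic acid or a methoxy group at this position would give a lower or a higher number than fluoro. They also leave open whether the change from fluoro to nitro would give a similar step on compound 3, which carries hydrogen in place of ethoxycarbonyl.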